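Compound 1 to compound 4: carbamoylmethoxy on the carbonyl

The source may report more compounds than this note shows. Statements on the series, on what has been measured and on what is new or still open speak of the compounds shown alone.

In an ADME assay on CEM-SS cells (Homo sapiens) for cytotoxicity, read by XTT assay, with a stated time of 6 days (a higher number here means that more compound is tolerated, a lower number that less compound is tolerated), compound 1 (`CCCC(=O)OCSc1ccccc1C(=O)NCCC(N)=O`) reads > 100 uM and this is a limit of the assay, not a number. Compound 2 (`CCCC(=O)OCSc1ccccc1C(=O)NCCCCCCNC(C)=O`) gives 8 uM in this assay and compound 3 (`CCCC(=O)OCSc1ccccc1C(=O)N[C@H]1CCC[C@@H]1C(N)=O`) gives 31.2 uM; 43.3 uM (2 entries) in the same test. Compound 4 (`CCCC(=O)OCSc1ccccc1C(=O)OCC(N)=O`) carries carbamoylmethoxy in place of (2-carbamoylethyl)amino on a carbonyl carbon. Within the data shown here, the one measured step (an at least 12-fold lower number from compound 1 to compound 2 (1.09 log units; beyond the scatter)) is large, but it sits on a saturated chain carbon, so it bears only loosely on this change. Among the measured compounds shown here, no step at the carbonyl carbon has been measured. A modest move towards a lower number is therefore expected, well short of that large step. The expected change is an at least 1.6-fold lower number from compound 1 to compound 4 (0.22 log units; that floor lies within the scatter) in this assay as a working estimate. Estimated for compound 4: 60 uM (from 20 uM to 150 uM).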

Compound 4, half-maximal toxic concentration: 82.1 uM
Beside the measured number, compound 4's estimate is 1.4-fold (0.14 log units) below it; low and high end bracket the measured number.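

Among these compounds, this is the one step measured on the carbonyl carbon: in this assay, carbamoylmethoxy in place of (2-carbamoylethyl)amino gives an at least 1.2-fold lower number from compound 1 to compound 4 (0.08 log units; that floor lies within the scatter). The change therefore shows no shift that can be told from the scatter, though that reading is only a floor. As far as these compounds go, compound 1 reads > 100 uM, which is a limit of the assay, so the true size of the step stays unknown: the limit of > 100 uM in this assay, at which 1 of the 4 values shown sits.

From the compounds shown here alone, how an amine or a carboxylic acid on this carbonyl carbon would read in this assay remains open. So does the effect of a longer chain ending in the carbamoyl group.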